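The compounds below may be only part of what the source reports. "The series", "measured", "known", "first", "only" and "open" are said of these compounds alone.

Measured in a functional assay on B16-F0 cells (Mus musculus) for inhibition, read by CCK-8 assay, with a stated time of 48 h; on this read-out higher numbers stand for weaker inhibition and lower numbers for stronger inhibition:
- compound 1 `COc1cc(-c2ccnc3cc(-c4cccc(C#N)c4)nn23)cc(OC)c1OC`: > 10000 nM (a limit of the assay, not a number)
- compound 2 `COc1cc(-c2ccnc3cc(-c4ccccc4)nn23)cc(OC)c1OC`: 4730 nM
- compound 3 `COc1cc(-c2ccnc3cc(-c4cn(C)c5ccccc45)nn23)cc(OC)c1OC`: 185 nM

Of the two actual numbers, the lower belongs to compound 3, and the gap is large: a 26-fold lower number from compound 2 to compound 3 (1.41 log units; beyond the scatter). The next compound to be tested is compound 4 `COc1cc(-c2ccnc3cc(-c4ccc(N(C)C)cc4)nn23)cc(OC)c1OC`, with 4-(dimethylamino)phenyl in place of 1-methyl-1H-indol-3-yl on an aromatic carbon.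

Among the compounds with values here, two measured steps bear on this change. The closest is a 26-fold lower number from compound 2 to compound 3 (1.41 log units; beyond the scatter), since compound 4 gives up the same 1-methyl-1H-indol-3-yl and returns to a six-membered carbon ring, as in compound 2. The other is an at least 2.1-fold lower number from compound 1 to compound 2 (0.32 log units; beyond the scatter), which shows that a substituent on that ring can move the number, though only in the case of compound 1. A sizeable move to a higher number is therefore expected, but less than the full reversal of the step to compound 3. The expected change is a 4.3-fold higher number from compound 3 to compound 4 (0.64 log units; beyond the scatter). For compound 4 the estimated value is 800 nM, with an expected range of 150 nM to 4500 nM.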

Compound 4, half-maximal inhibitory concentration: 702 nM
The estimate for compound 4 lay 1.1-fold (0.06 log units) above the measured number, within the range that was stated.
By their numbers in this assay, from the lowest: compound 3; then compound 4; then compound 2. At a limit, above all of these: compound 1.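

In this assay, a substituent on the six-membered carbon ring can lower the number as well as raise it: dimethylamino in place of hydrogen gives a 6.7-fold lower number from compound 2 to compound 4 (0.83 log units; beyond the scatter), yet 1-methyl-1H-indol-3-yl keeps its lead, with a 3.8-fold higher number from compound 3 to compound 4 (0.58 log units; beyond the scatter), so 4-(dimethylamino)phenyl recovers only part of the gap. Against 3-cyanophenyl, the new group gives an at least 14-fold lower number from compound 1 to compound 4 (1.15 log units; beyond the scatter), and the true size of this step stays unknown. Compound 1 stands at a limit of the assay, not a number: the limit of > 10000 nM in this assay, at which 1 of the 4 values shown sits.

Open, on these data alone, is whether the gain depends on where dimethylamino sits on the ring, and whether a plain amino group or morpholine would serve in its place. Also open, as far as these compounds go, is what the methyl group of 1-methyl-1H-indol-3-yl contributes, compared with 1H-indol-3-yl.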